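The source may hold more compounds than are shown below. What is called first, only, known or untested is meant among the compounds shown, and "the series" means these compounds.

Measured compounds in the series:
- compound 1, `COc1ccc(Cl)cc1NC(=O)CN1CCN(S(=O)(=O)N2CCC(C)CC2)[C@H](C)C1`: 13000 nM
- compound 2, `COc1ccc(Cl)cc1NC(=O)CN1CCN(S(=O)(=O)N2CCC(C)CC2)C[C@@H]1C`: 3500 nM
- compound 3, `CC1CCN(S(=O)(=O)N2CCN(CC(=O)Nc3cc(Cl)ccc3OCC3CC3)CC2)CC1`: 7500 nM

All three numbers come from an assay on HEK293 cells for inhibition of potassium channel subfamily T member 1 (Homo sapiens), read by thallium flux; on this read-out lower numbers stand for stronger inhibition and higher numbers for weaker inhibition. Compound 1 carries the highest number of the three. Its gap to compound 3 is within the scatter, so the two are not ordered against each other; its gap to compound 2 is beyond the scatter, with compound 2 at the lower number.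

Compound 4, `COc1ccc(Cl)cc1NC(=O)CN1CCN(S(=O)(=O)N2CCC(C)CC2)[C@@H](C)C1`, is not yet measured. It relates to compound 1 as follows: the two compounds have the same atoms and bonds and differ only in configuration as drawn: 1 of 1 stereo elements differ; a stereocentre at a saturated ring carbon is drawn R in compound 1 and S in compound 4. Among the measured compounds shown here, no pair of measured compounds shows a step of this kind, so nothing in the set tells how large a step, or in which direction, a change of configuration at this ring carbon brings. What the set does show is that compound 1 stands at the high end of the three numbers, so there is more room for compound 4 to fall below it than to rise above it.

Working expectation for compound 4 in this assay: a moderate step toward a lower number, a 2.2-fold lower number from compound 1 to compound 4 (0.34 log units; beyond the scatter), but with no measured step to lean on the range is kept wide. Compound 4 is expected at 6000 nM, between 2000 nM and 20000 nM.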

Compound 4, half-maximal inhibitory concentration: > 10000 nM
Compound 4: no number, only a limit; the forecaster's own chance of this, stated with the estimate: 15%; at least 1.6-fold (0.22 log units) between middle value and limit.
By their numbers in this assay, from the lowest: compound 2; then compounds 3 and 1 (each within the scatter of the next).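

In this assay compound 4 gives > 10000 nM, which is a limit of the assay and not a number. The step between compound 1 and compound 4 therefore cannot be read. The compounds shown leave open how large a change the configuration at this saturated ring carbon brings, and in which direction.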